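Fluorocyclopropyl amides: one stereocentre flipped from compound 3

The source may report more compounds than this note shows. Statements on the series, on what has been measured and on what is new or still open speak of the compounds shown alone.

Working notes on a small amide series built on one shared core. In an assay on SH-EP1 cells for displacement of a labelled ligand from Neuronal acetylcholine receptor; alpha4/beta2 (Homo sapiens), read by scintillation counting (on this read-out higher numbers stand for weaker inhibition and lower numbers for stronger inhibition), compound 1 `CCCC(=O)N1CC2CC(C1)N2` gives 14 nM. Compound 2 `O=C([C@H]1C[C@H]1F)N1CC2CC(C1)N2` gives 1.1 nM in this assay, and compound 3 `O=C([C@@H]1C[C@@H]1F)N1CC2CC(C1)N2` gives 1.7 nM. Among the three numbers compound 3 stands second highest; the nearest is compound 2, with a 1.5-fold higher number from compound 2 to compound 3 (0.19 log units; within the scatter), and the furthest is compound 1, with an 8.2-fold lower number from compound 1 to compound 3 (0.92 log units; beyond the scatter). The same replacement of propyl by 2-fluorocyclopropyl on the carbonyl carbon is seen in a 13-fold lower number from compound 1 to compound 2 (1.10 log units; beyond the scatter).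

Compound 4 `O=C([C@@H]1C[C@H]1F)N1CC2CC(C1)N2` has not yet been measured in this assay. It differs from compound 3 as follows: the two compounds have the same atoms and bonds; at least one stereo element is drawn with a configuration in one of them and without one in the other: 1 of 4 stereo elements differ; a stereocentre at a saturated ring carbon is drawn S in compound 3 and R in compound 4. Within the data shown here, the only measured step of a comparable kind is the stereo pair, a 1.5-fold higher number from compound 2 to compound 3 (0.19 log units; within the scatter), and it turns on (the fact that one of compounds 2 and 3 is drawn with a defined configuration and the other without, at the place where they differ). On that basis a step beyond the scatter is not expected for compound 4 in this assay, in either direction. The estimate for compound 4 is 2.5 nM, with a range from 0.8 nM to 8 nM, which corresponds to an expected 1.5-fold higher number from compound 3 to compound 4 (0.17 log units; within the scatter).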

Compound 4, inhibition constant: 1 nM
Estimate against measurement, compound 4: 2.5-fold (0.40 log units) above; low and high end bracket the measured number.
By their numbers in this assay, from the lowest: compounds 4, 2 and 3 (each within the scatter of the next); then compound 1.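

In this assay, changing a single stereocentre gives a 1.7-fold lower number from compound 3 to compound 4 (0.23 log units; within the scatter), and the other single-centre pair gives a 1.1-fold lower number from compound 2 to compound 4 (0.04 log units; within the scatter); the single-centre changes thus stay within the scatter, as the two-centre change between compound 2 and compound 3 does. The replacement of propyl by 2-fluorocyclopropyl also holds in a third stereo form, with a 14-fold lower number from compound 1 to compound 4 (1.15 log units; beyond the scatter), so all three fluorocyclopropyl amides shown stand clear of the propyl amide. The stereo comparison carries one limit in how the structures are drawn: the fact that one of compounds 3 and 4 is drawn with a defined configuration and the other without, at the place where they differ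

Going by these compounds, whether the step from propyl belongs to the ring or to the fluorine stays open, and a plain cyclopropyl amide on the shared core would separate the two. The compounds shown also give no reading of a 2-methylcyclopropyl group in place of the 2-fluorocyclopropyl group.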